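The compounds below may be only part of what the source reports. "The series", "measured", "known", "first", "only" and "open" are said of these compounds alone.

Three compounds have numbers in a functional assay on HCT-116 cells (Homo sapiens) for antiproliferative activity, read by CCK-8 assay, with a stated time of 72 h, tested at 2 uM; a higher number here means a stronger effect of the compound at the concentration tested, a lower number a weaker effect. Compound 2 `Nc1ccccc1NC(=O)/C=C/c1ccc(Cn2cnc3c(Nc4cccc(Cl)c4)nc(Cl)nc32)cc1` gives 12.9%, the highest of the three, yet within the scatter of compound 1 `CC(C)n1cnc2c(Nc3cccc(Cl)c3)nc(NCOCc3ccc(C(=O)Nc4ccccc4N)cc3)nc21` at 7.12% and of compound 3 `CCCCn1cnc2c(Nc3ccccc3)nc(NCOCc3ccc(/C=C/C(=O)Nc4ccccc4N)cc3)nc21` at 6.58%, so no order among them is claimed. Compound 4 `Nc1ccccc1NC(=O)/C=C/c1ccc(Cn2cnc3c(NCc4ccccc4)nc(Cl)nc32)cc1` is not yet measured. It differs from compound 2 by one change: benzyl in place of 3-chlorophenyl on a nitrogen on an aromatic ring. Going by the values given here, no measured pair shows this change, so no step size is known for it. All three measured values sit low and close together, so the step from compound 2 to compound 4 is expected to be small, no further than the scatter, in either direction. Compound 4 is expected to give 10%, between 2% and 22%. The expected step is a number 2.9 percentage points lower from compound 2 to compound 4 (within the scatter), within the scatter.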

Compound 4, a percentage reported as inhibition, at one concentration (the size of the read-out at that concentration, not a potency): 2.85%
For compound 4 the middle estimate is 7.2 percentage points above the measured one; low and high end bracket the measured number.
By their numbers in this assay, from the lowest: compounds 4, 3, 1 and 2 (each within the scatter of the next, the first and the last beyond it).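

In this assay, this position, on a nitrogen on an aromatic ring, now has its first step of known size: a number 10.1 percentage points lower from compound 2 to compound 4 (beyond the scatter). Exchanging (3-chlorophenyl)amino for benzylamino therefore registers at this nitrogen, even though both groups carry one six-membered aromatic ring of carbon only. No available measurement bears on why the number falls.

The compounds shown do not separate the loss of chlorine from the change from phenyl to benzyl, which a 3-chlorobenzyl or plain phenyl group on this nitrogen could address. On these data alone, whether an aliphatic amine or a longer chain here would raise the effect remains open.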